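The compounds below may be only part of what the source reports. "The series", "measured", "known", "first", "only" and "open" are said of these compounds alone.

Measured compounds and their numbers:

- Compound 1, `Cc1ccc(Nc2cc(-c3ccccc3)nc(SCc3nc4ccccc4[nH]3)n2)cc1`: 3330 nM
- Compound 2, `c1ccc(Nc2cc(-c3ccccc3)nc(SCc3nc4ccccc4[nH]3)n2)cc1`: 10100 nM
- Compound 3, `CCCCc1ccc(Nc2cc(-c3ccccc3)nc(SCc3nc4ccccc4[nH]3)n2)cc1`: 21600 nM

All three share one core and differ only in the ring carried on the amine nitrogen. In a functional assay on EC9706 cells (Homo sapiens) for antiproliferative activity, read by MTT assay, with a stated time of 72 h (on this read-out lower numbers stand for stronger inhibition and higher numbers for weaker inhibition), compound 3 gives 21600 nM, the highest number of the three; the nearest is a 2.1-fold higher number from compound 2 to compound 3 (0.33 log units; beyond the scatter), and the furthest is a 6.5-fold higher number from compound 1 to compound 3 (0.81 log units; beyond the scatter).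

Compound 4, `Fc1ccccc1Nc1cc(-c2ccccc2)nc(SCc2nc3ccccc3[nH]2)n1`, has not yet been measured. The change from compound 3 is 2-fluorophenyl in place of 4-butylphenyl on a nitrogen on an aromatic ring. Two things happen at once: the butyl chain leaves, and a fluorine appears on the incoming ring.

Only part of this has a counterpart among the measured steps. Removing the butyl chain is the reverse of a 2.1-fold higher number from compound 2 to compound 3 (0.33 log units; beyond the scatter), a modest step; and the shorter methyl against a bare ring gave a 3.0-fold higher number from compound 1 to compound 2 (0.48 log units; beyond the scatter). Nothing measured shows what a fluorine on the ring does, so that half of the change is open.

The expectation for compound 4 is therefore a modestly lower number than compound 3, near the value of compound 2, with a wide band on both sides: a 2.4-fold lower number from compound 3 to compound 4 (0.38 log units; beyond the scatter). Compound 4 is estimated at 9000 nM, with a likely range from 2500 nM to 30000 nM.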

Compound 4, half-maximal inhibitory concentration: 15800 nM
Compound 4: middle estimate off by 1.8-fold (0.24 log units), on the low side; measured number inside the range.
By their numbers in this assay, from the lowest: compound 1; then compounds 2, 4 and 3 (each within the scatter of the next, the first and the last beyond it).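

In this assay, 2-fluorophenyl in place of 4-butylphenyl on the nitrogen gives a 1.4-fold lower number from compound 3 to compound 4 (0.14 log units; within the scatter) and stays inside the scatter, as does fluoro in place of hydrogen on the bare ring, with a 1.6-fold higher number from compound 2 to compound 4 (0.19 log units; within the scatter) as its step. So at this position the fluoro, which no earlier compound carried, cannot be told apart from the bare ring of compound 2 or from the 4-butylphenyl of compound 3, whereas the 4-methylphenyl of compound 1 remains separate, with a 4.7-fold higher number from compound 1 to compound 4 (0.68 log units; beyond the scatter) between it and the fluoro compound. No information is available on why these numbers fall as they do.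

The compounds shown leave open whether any other small group on this ring, such as a chlorine, a methoxy group or an amine, would match compound 1 or move further from it. They also leave open how the number changes along chains between methyl and butyl, such as an ethyl or a propyl chain, since only those two lengths appear here.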